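The compounds below may be only part of what the source reports. "The series", "measured", "known", "first", "only" and "open" are said of these compounds alone.

Compound 1 `CN(C)CCCCCSC1=Nc2ccccc2C(CC(=O)NCc2ccccc2)N1c1ccc(-c2ccc(F)cc2)cc1` is the stronger of the two measured compounds. In an assay on cells for inhibition of Voltage-dependent T-type calcium channel subunit alpha-1G (Homo sapiens), read by patch clamp (on this read-out higher numbers stand for weaker inhibition and lower numbers for stronger inhibition), compound 1 gives 250 nM, the lowest number among the two, while compound 2 `CN(C)CCCCCSC1=Nc2ccccc2C(CC(=O)NCc2ccccc2)N1c1ccccc1` gives 18500 nM. Within the data shown here, the only measured step is the loss of the 4-fluorophenyl group from the ring on the core nitrogen, which brings a 74-fold higher number from compound 1 to compound 2 (1.87 log units; beyond the scatter) and shows that this part of the molecule matters a great deal.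

Compound 3 `CN(C)CCCCCSC1=Nc2ccccc2C(CC(=O)NCc2ccc(F)cc2)N1c1ccc(-c2ccc(F)cc2)cc1` differs from compound 1 at another place entirely: fluoro in place of hydrogen on an aromatic carbon on the benzyl group of the amide, giving a (4-fluorobenzyl)amino group. Among the measured compounds shown here, no measured step touches this benzyl group, so there is nothing among the two measured compounds that speaks directly for or against the change, and the large step from compound 1 to compound 2 concerns a different position. The expectation is therefore a step of no clear size, no change at the digits printed from compound 1 to compound 3 (within the scatter), that stays within the scatter. Compound 3 is estimated at 250 nM in this assay, with a range from 100 nM to 650 nM.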

Compound 3, half-maximal inhibitory concentration: 400 nM
Compound 3: middle estimate off by 1.6-fold (0.20 log units), on the low side; the range from low to high includes it.
By their numbers in this assay, from the lowest: compounds 1 and 3 (each within the scatter of the next); then compound 2.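

In this assay, fluoro in place of hydrogen on an aromatic carbon of the benzyl group brings a 1.6-fold higher number from compound 1 to compound 3 (0.20 log units; within the scatter), so this read-out cannot tell compound 1 and compound 3 apart. Among these compounds, this is the first measured change on the benzyl group of the amide, and it shows that a single fluoro at this place, para to a large group, leaves the inhibition within the usual scatter of repeated measurements, quite unlike the large step at the other end of the molecule, a 74-fold higher number from compound 1 to compound 2 (1.87 log units; beyond the scatter). No measured information is available to explain why the fluoro has so little visible effect here.

From the compounds shown here alone, one fluoro at one place is only a small probe of the benzyl group, so it remains open whether a chloro, methoxy or trifluoromethyl group at the same place would also stay within the scatter, or whether a fluoro elsewhere on that ring would behave alike. Going by these compounds, it is equally open how a 2-phenylethyl group, with a longer chain between the amide nitrogen and the ring, or a cyclohexylmethyl group in place of the benzyl group would fare in this assay.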